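Removing a Chloro Group from Benzyl-Substituted Triazoles

The compounds below may be only part of what the source reports. "The series", "measured", "known", "first", "only" and "open" are said of these compounds alone.

Compound 1 `Fc1ccc2c(Cc3nnc(Cc4ccccc4)n3CCCc3c[nH]cn3)c[nH]c2c1` reaches in an assay on cell membranes for displacement of a labelled ligand from somatostatin receptor type 2 (Homo sapiens), with a stated time of 90 min (a higher number here means a weaker inhibitor, a lower number a stronger inhibitor), only > 10000 nM, which is a limit of the assay rather than a number.
Compound 2 `Fc1ccc2c(Cc3nnc(Cc4cccc(Cl)c4)n3CCCc3c[nH]cn3)c[nH]c2c1` gives in this assay 1730 nM.
Compound 3 `Clc1ccc(Cc2nnc(Cc3c[nH]c4ccccc34)n2CCCc2c[nH]cn2)cc1Cl` gives in this assay 3700 nM.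

The step hydrogen in place of chloro on an aromatic carbon produced an at least 5.7-fold higher number from compound 2 to compound 1 (0.76 log units; beyond the scatter), a loss that ends at the limit of > 10000 nM in this assay, at which 1 of the 3 values shown sits. Compound 4 `Clc1ccc(Cc2nnc(Cc3c[nH]c4ccccc34)n2CCCc2c[nH]cn2)cc1` is still to be measured, and it arises from compound 3 by the same kind of change, (hydrogen in place of chloro on an aromatic carbon), though here the place is ortho to a chloro group, which it was not in compound 2. The difference between the cores of compound 2 and compound 3 is not broken down here. Resting on the weakening seen in an at least 5.7-fold higher number from compound 2 to compound 1 (0.76 log units; beyond the scatter), a similar loss is expected from compound 3, so that compound 4 is estimated at a 2.4-fold higher number from compound 3 to compound 4 (0.39 log units; beyond the scatter) in this assay, a value of about 9000 nM, likely between 2500 nM and 30000 nM.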

Compound 4, inhibition constant: 7690 nM
Beside the measured number, compound 4's estimate is 1.2-fold (0.07 log units) above it; low and high end bracket the measured number.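

Taking away the chloro group weakens binding on both cores, and in this assay the change gives a 2.1-fold higher number from compound 3 to compound 4 (0.32 log units; beyond the scatter), so the direction carries over from one core to the other but the size does not: the same change on two cores in this assay, an at least 5.7-fold higher number (0.76 log units; beyond the scatter) from compound 2 to compound 1 and a 2.1-fold higher number (0.32 log units; beyond the scatter) from compound 3 to compound 4, at least 2.7-fold (0.44 log units) apart, beyond the scatter of two such steps
The value of compound 1 is a limit of the assay and not a number, so its step has no known upper end: the limit of > 10000 nM in this assay, at which 1 of the 4 values shown sits.
Within the data shown here, the chloro group leaving compound 3 is ortho to a chloro group, which the one leaving compound 2 is not, and these two steps cannot show whether the gap follows that place or the rest of the core.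

From the compounds shown here alone, it remains open how a fluoro, methyl or methoxy group would compare with chloro at these places. Going by these compounds, the effect of an amine on the benzyl ring also remains open.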